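A few compounds are considered here, and "the series" means these few. Any claim that something is new, unique, unknown or untested is made for them only; others in the source may bear on it.

Measured so far:
compound 1 `Cc1ccc(F)cc1NC[C@@H]1[C@@H](c2ccc(S(N)(=O)=O)cc2)C1(C)C`: 10%
compound 2 `CC1(C)[C@H](CNc2ccc(F)cc2C(F)(F)F)[C@H]1c1ccc(S(N)(=O)=O)cc1`: -9%
compound 3 `CC1(C)[C@@H](CNc2ccc(F)cc2OC(F)F)[C@@H]1c1ccc(S(N)(=O)=O)cc1`: 51%

In a functional assay on the whole organism with Mus musculus as the target, with stated times of 60 min and 30 min, at a dose of 10 mg/kg by the oral route (on this read-out higher numbers stand for more inhibition at the one dose given (going by the name of the read-out) and lower numbers for less inhibition), compound 1 stands second highest of the three. Its nearest neighbour is compound 2, whose reading lies below it by a margin beyond the usual scatter; compound 3 is the furthest off, well above it, also beyond the scatter.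

Compound 4 `Cc1cc(F)c(F)cc1NC[C@@H]1[C@@H](c2ccc(S(N)(=O)=O)cc2)C1(C)C` is not yet measured. Relative to compound 1 it carries fluoro in place of hydrogen on an aromatic carbon. Among the measured compounds shown here, no measured pair shows this same change, so the size of the step rests on judgement only. A modest rise in this assay is expected, of about a number 12 percentage points higher from compound 1 to compound 4 (beyond the scatter), though a change within the scatter cannot be ruled out. For compound 4 the estimate is 22%, with a range from 0% to 45%.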

Compound 4, a percentage reported as inhibition, in the whole organism at one dose (the size of the read-out at that dose, not a potency): 15%
The estimate for compound 4 lay 7 percentage points above the measured number; low and high end bracket the measured number.
By their numbers in this assay, from the lowest: compound 2; then compounds 1 and 4 (each within the scatter of the next); then compound 3.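

Fluoro in place of hydrogen on this aromatic carbon, ortho to a fluoro group and para to a large group, gives in this assay a number 5 percentage points higher from compound 1 to compound 4 (within the scatter) and so leaves compound 1 and compound 4 indistinguishable on this read-out. At this one dose, the position accepts the added fluoro with no reading beyond the scatter. No data on these compounds speak to the reason for this result. On these data alone, whether a methoxy group or an amine on the same carbon would read alike remains open.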